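Hydrazone Replaces Trifluoromethylphenyl on a Urea Nitrogen

The compounds below may be only part of what the source reports. "The series", "measured", "known", "first", "only" and "open" are said of these compounds alone.

Compound 2 `COc1cc2c(Oc3ccc(NC(=O)Nc4ccccc4C(F)(F)F)cc3)ccnc2cc1OCCCCCCC(=O)NO` and compound 1 `COc1cc2c(Oc3ccc(NC(=O)Nc4cccc(C)c4)cc3)ccnc2cc1OCCCCCCC(=O)NO` share a core that carries a long chain ending in a hydroxamic acid. In a functional assay on MCF7 cells (Homo sapiens) for antiproliferative activity, read by MTT assay (on this read-out lower numbers stand for stronger inhibition and higher numbers for weaker inhibition), compound 1 gives 1240 nM, and compound 2 gives 1080 nM. The step of a 1.1-fold lower number from compound 1 to compound 2 (0.06 log units; within the scatter) is the only measured one; compound 2 therefore holds the lowest of two numbers, but within the scatter of compound 1. Compound 3 `COc1cc2c(Oc3ccc(NC(=O)N/N=C/c4ccccc4F)cc3)ccnc2cc1OCCCCCCC(=O)NO` differs from compound 2 as follows: a group of 9 heavy atoms (7 carbon, 1 nitrogen, 1 fluorine; one six-membered aromatic ring of carbon only) in place of a group of 10 heavy atoms (7 carbon, 3 fluorine; one six-membered aromatic ring of carbon only), on an amide-type nitrogen. For the measured compounds named here, no measured step touches a group of this kind on the amide-type nitrogen, and the one known exchange at that place did not move the number beyond the scatter, so a step of no more than the scatter is expected in this assay, with no clear direction. Compound 3 is expected to give about 1200 nM, in the range 400 nM to 3600 nM, which is the step of a 1.1-fold higher number from compound 2 to compound 3 (0.05 log units; within the scatter) and is expected to stay near compound 2.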

Compound 3, half-maximal inhibitory concentration: 1610 nM
Compound 3: middle estimate off by 1.3-fold (0.13 log units), on the low side; the measured number falls inside the stated range.
By their numbers in this assay, from the lowest: compounds 2, 1 and 3 (each within the scatter of the next).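

In this assay, exchanging the group on the amide-type nitrogen for the hydrazone-bearing group of compound 3 leaves the number within the scatter of both earlier compounds: a 1.5-fold higher number from compound 2 to compound 3 (0.17 log units; within the scatter) and a 1.3-fold higher number from compound 1 to compound 3 (0.11 log units; within the scatter). For the compounds shown here, the earlier step compared only two substituted phenyl groups, whereas this position now also accommodates a group with a double bond outside aromatic rings and a hydrogen-bond acceptor, without separating the three compounds. No accompanying measurement bears on this result.

All three compounds retain the shared core, the hydroxamic acid chain and a six-membered aromatic ring of carbon only in the exchanged group, leaving open whether an amine or a carboxylic acid on the amide-type nitrogen would move the number beyond the scatter. On these data alone, the contribution of the fluorine in compound 3 also stays open, as does the effect of a shorter chain ending in the hydroxamic acid.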